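Coumarin-isoxazole series: nitro for chloro, cytotoxicity

This account rests on a few compounds, and the source may have more. Where it says the series, first, only, none or still open, it means among the compounds named here.

Measured so far:
compound 1 `O=c1ccc2cc(OCc3cc(-c4ccccc4Cl)no3)ccc2o1` — "not determined" (no result reported)
compound 2 `O=c1ccc2cc(OCc3cc(-c4ccc5ccccc5c4)no3)ccc2o1` — 55700 nM
compound 3 `O=c1ccc2cc(OCc3cc(-c4ccc(Cl)cc4)no3)ccc2o1` — 44600 nM

In a functional assay on HL-60 cells (Homo sapiens) for cytotoxicity, read by MTT assay, with a stated time of 48 h (a higher number here means a weaker inhibitor, a lower number a stronger inhibitor), compound 3 gives the lower of the two numbers on hand, and compound 2 sits a small step above it, a gap within the scatter. Compound 1 has no result in this assay.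

Compound 4 `O=c1ccc2cc(OCc3cc(-c4ccc([N+](=O)[O-])cc4)no3)ccc2o1` differs from compound 3 in one place: nitro in place of chloro on an aromatic carbon. Among the compounds with values here, no pair of measured compounds shares this change, so the size of the step is not backed by any data here.

The step expected is a 1.1-fold lower number from compound 3 to compound 4 (0.05 log units; within the scatter), not beyond the scatter in either direction. The value expected for compound 4 is 40000 nM, with a range from 15000 nM to 120000 nM.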

Compound 4, half-maximal inhibitory concentration: 55800 nM
For compound 4 the middle estimate is 1.4-fold (0.14 log units) below the measured one, and the stated range covers the measured number.
By their numbers in this assay, from the lowest: compounds 3, 2 and 4 (each within the scatter of the next).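

Within the data shown here, with the 4-chlorophenyl to 4-nitrophenyl change, this assay shows a 1.3-fold higher number from compound 3 to compound 4 (0.10 log units; within the scatter) for the first single-place comparison. Among these compounds, at this aromatic carbon, a nitro group with its two hydrogen-bond acceptors thus gives a number within the scatter of the chloro compound, although only this one change has been read. No measurement here bears on the cause of this result.

Still open, going by these compounds, is whether an amine or a carboxylic acid on the same aromatic carbon would give a number beyond the scatter of compound 3. On these data alone, with compound 1 unresolved in this assay, the effect of moving chloro around the ring also remains unknown.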